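Cytotoxicity in the ether series: methoxy to chlorophenyl

The source may report more compounds than this note shows. Statements on the series, on what has been measured and on what is new or still open speak of the compounds shown alone.

Compound 1 `COc1ccc(COc2ccc3c(c2)[C@@H](O)CN(C)C3)cc1` is the reference point of the step considered here. In an ADME assay on Vero cells (Chlorocebus sabaeus) for cytotoxicity, read by sulforhodamine B assay, with a stated time of 72 h (a lower number here means a stronger inhibitor, a higher number a weaker inhibitor), compound 1 gives > 50000 nM, which is a limit of the assay and not a number. Compound 2 `CN1Cc2ccc(OCc3cccnc3)cc2[C@@H](O)C1` is a close relative. In this assay compound 2 gives > 50000 nM, again a limit and not a number. For the measured compounds named here, compound 3 `CN1Cc2ccc(OC(c3ccccc3)(c3ccccc3)c3ccccc3)cc2[C@@H](O)C1` is the only compound with a numerical result. In this assay compound 3 gives 87900 nM. Compound 1 therefore stands at the limit of > 50000 nM in this assay, at which 2 of the 3 values shown sit, and nothing shown separates it from the other two compounds; no step between measured compounds is available for this series.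

Compound 4 `CN1Cc2ccc(OCc3ccc(-c4cccc(Cl)c4)cc3)cc2[C@@H](O)C1` differs from compound 1 by 3-chlorophenyl in place of methoxy on an aromatic carbon. Going by the values given here, with no measured step to lean on, only a modest move toward stronger inhibition, if any, is expected, since compound 3 carries a large group and still gives 87900 nM. The step from compound 1 to compound 4 is expected to be an at least 1.2-fold lower number from compound 1 to compound 4 (0.09 log units; that floor lies within the scatter). Compound 4 is estimated at 40000 nM, within 12000 nM to 100000 nM.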

Compound 4, half-maximal inhibitory concentration: 25500 nM
Compound 4: the middle estimate sits 1.6-fold (0.20 log units) above what was measured, within the range that was stated.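

For the compounds shown here, at the aromatic carbon para to a large group, 3-chlorophenyl in place of methoxy gives the first step that can be read in this assay: an at least 1.9-fold lower number from compound 1 to compound 4 (0.29 log units; that floor lies within the scatter). Compound 1 gives > 50000 nM, which is a limit of the assay and not a number. The step can only be a floor, and compound 4 is the compound that supplies its numerical end, because compound 1 stands at a limit: the limit of > 50000 nM in this assay, at which 2 of the 4 values shown sit.

On these data alone, the true size of the step stays open, including whether it lies beyond the scatter. The compounds shown also do not separate the added aromatic ring from its chlorine, and an unsubstituted phenyl, a 4-chlorophenyl or a basic amine such as morpholine on the same carbon would address that question.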